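The compounds below may be only part of what the source reports. "The series", "measured", "known", "first", "only" and "open" are said of these compounds alone.

Compound 2 `COc1cc(OCc2cccc(-c3cnc(OC)nc3)c2)c2cc(-c3cn4nc(OC)sc4n3)oc2c1` and compound 1 `COc1cc(OCc2cccc(-c3ccc(OC)nc3)c2)c2cc(-c3cn4nc(OC)sc4n3)oc2c1` are the two compounds that have been measured in an ADME assay on the whole organism (Rattus norvegicus), at a dose of 2 mg/kg by the oral route; on this read-out lower numbers stand for lower exposure and higher numbers for higher exposure at the dose given. In this assay compound 2 gives 1030 ng.h/mL, while compound 1 gives 1800 ng.h/mL; the step is a 1.7-fold lower number from compound 1 to compound 2 (0.24 log units; within the scatter), so the two compounds sit within the scatter of each other and no order between them can be claimed. Compound 3 `COc1cc(OCc2cccc(OCc3ccccc3)c2)c2cc(-c3cn4nc(OC)sc4n3)oc2c1` differs from compound 2 in one place: benzyloxy in place of 2-methoxypyrimidin-5-yl on an aromatic carbon. For the measured compounds named here, the only measured step that bears on this change is the one from compound 1 to compound 2, which also exchanged the group at this position and stayed within the scatter; it is a weak guide, since it swapped one six-membered ring with hetero atoms for another, whereas here a ring of carbon only enters with a benzyloxy link. Compound 3 is therefore expected to show a 1.3-fold lower number from compound 2 to compound 3 (0.11 log units; within the scatter), a step not clearly beyond the scatter, with an estimated value of 800 ng.h/mL in the range 300 ng.h/mL to 2000 ng.h/mL.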

Compound 3, area under the concentration-time curve: 339 ng.h/mL
The estimate for compound 3 lay 2.4-fold (0.37 log units) above the measured number, and the stated range covers the measured number.
By their numbers in this assay, from the lowest: compound 3; then compounds 2 and 1 (each within the scatter of the next).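

In this assay, this position proved able to move the number beyond the scatter, which the exchange of one six-membered aromatic ring with hetero atoms for another had not shown: benzyloxy brings a 3.0-fold lower number from compound 2 to compound 3 (0.48 log units; beyond the scatter) and a 5.3-fold lower number from compound 1 to compound 3 (0.73 log units; beyond the scatter). Both steps run the same way, so among these three compounds, compound 3 gives the lowest number, whichever of the two rings it is set against. Nothing measured on these compounds accounts for the step.

Since the ring of carbon only and the oxygen-bearing benzyloxy link enter together, the compounds shown cannot tell which of the two goes with the lower number. On these data alone, how a morpholine or a carboxylic acid at this place would read in this assay also stays open.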